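Lengthening the ether chain toward a saturated ring

This account rests on a few compounds, and the source may have more. Where it says the series, first, only, none or still open, it means among the compounds named here.

The three measured compounds share one core and differ only in the group on the ether oxygen of the aromatic ring. Compound 1 `O=C1N=C(O)S/C1=C\c1ccc(OCCc2ccsc2)cc1` gives 60 nM in an assay for inhibition of 15-hydroxyprostaglandin dehydrogenase [NAD(+)] (Homo sapiens), read by fluorescence and spectrophotometry; a lower number here means a stronger inhibitor, a higher number a weaker inhibitor. Compound 2 `O=C1N=C(O)S/C1=C\c1ccc(OCCc2ccccn2)cc1` gives 660 nM, and compound 3 `O=C1N=C(O)S/C1=C\c1ccc(OCc2ccsc2)cc1` gives 429 nM. Compound 3 thus stands second highest of the three numbers; its gap to compound 2 lies within the scatter, while a 7.2-fold higher number from compound 1 to compound 3 (0.85 log units; beyond the scatter).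

Compound 4 `O=C1N=C(O)S/C1=C\c1ccc(OCCC2CCCC2)cc1` differs from compound 3 in one place: cyclopentylmethyl in place of thiophen-3-yl on a saturated chain carbon bound to an oxygen on an aromatic ring. Going by the values given here, two measured steps bear on this. The step from compound 3 back to compound 1 shows that one added chain carbon before the ring was worth a modest gain, and an 11-fold higher number from compound 1 to compound 2 (1.04 log units; beyond the scatter) shows that swapping one ring for another can move the number a lot. Among the compounds with values here, compound 4 takes the longer chain but also exchanges the aromatic ring for a saturated one, for which no measured pair exists. On balance a gain of modest size is expected, a 2.9-fold lower number from compound 3 to compound 4 (0.46 log units; beyond the scatter), so that compound 4 is estimated at 150 nM, within 40 nM to 600 nM.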

Compound 4, half-maximal inhibitory concentration: 116 nM
For compound 4 the middle estimate is 1.3-fold (0.11 log units) above the measured one, and the stated range covers the measured number.
By their numbers in this assay, from the lowest: compounds 1 and 4 (each within the scatter of the next); then compounds 3 and 2 (each within the scatter of the next).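

In this assay, cyclopentyl on the saturated chain carbon, two bonds along the chain from an oxygen on an aromatic ring, shows a 1.9-fold higher number from compound 1 to compound 4 (0.29 log units; within the scatter) against thiophen-3-yl, so a non-aromatic ring of carbon only can take the place of that aromatic ring without a change beyond the scatter. The same group gives a 5.7-fold lower number from compound 2 to compound 4 (0.76 log units; beyond the scatter) against pyridin-2-yl, and the change from (thiophen-3-yl)methyl to 2-cyclopentylethyl gives a 3.7-fold lower number from compound 3 to compound 4 (0.57 log units; beyond the scatter) while altering both chain length and ring. Nothing available explains these differences.

Going by these compounds, how much of that last step belongs to the chain and how much to the ring remains open, and a cyclopentyl group on the shorter chain would separate the two. Also open, on these data alone, is whether cyclohexyl or a longer chain such as 3-cyclopentylpropyl would be tolerated at this position.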